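Swapping the thiophene arm of compound 1 for a methoxyphenyl

This account rests on a few compounds, and the source may have more. Where it says the series, first, only, none or still open, it means among the compounds named here.

The measured compounds and their values:
- compound 1, `COc1cc(C(=O)c2sc(-c3cccs3)cc2N)cc(OC)c1OC`: 8.9 nM
- compound 2, `COc1cc(C(=O)c2sc(-c3ccc(Cl)cc3)cc2N)cc(OC)c1OC`: 77 nM
- compound 3, `COc1cc(C(=O)c2sc(-c3ccccc3)cc2N)cc(OC)c1OC`: 5.3 nM

All three share one core and differ only in the aromatic group attached to it. In a functional assay on MOLT-4 cells (Homo sapiens) for antiproliferative activity (a higher number here means a weaker inhibitor, a lower number a stronger inhibitor), compound 1 gives 8.9 nM. It sits between the other two: close to compound 3, with a 1.7-fold lower number from compound 1 to compound 3 (0.23 log units; within the scatter), and far from compound 2, with an 8.7-fold higher number from compound 1 to compound 2 (0.94 log units; beyond the scatter). Compound 3 against compound 2 shows a 15-fold lower number from compound 2 to compound 3 (1.16 log units; beyond the scatter).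

Compound 4, `COc1cccc(-c2cc(N)c(C(=O)c3cc(OC)c(OC)c(OC)c3)s2)c1`, has not been measured. It differs from compound 1 by 3-methoxyphenyl in place of thiophen-2-yl on an aromatic carbon.

For the measured compounds named here, two measured steps bear on this. Replacing thiophen-2-yl by a plain phenyl, in compound 3, left the number where it was. Adding a substituent to that phenyl, in compound 2, raised the number clearly. Going by the values given here, compound 4 carries a phenyl with a methoxy substituent, so a rise beyond the scatter is expected, though a methoxy group at the 3-position has no direct precedent here, and a smaller change is possible. The estimated step is a 2.0-fold higher number from compound 1 to compound 4 (0.31 log units; beyond the scatter). Compound 4 is therefore expected to give about 18 nM in this assay, most likely between 5 nM and 65 nM.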

Compound 4, half-maximal inhibitory concentration: 17 nM
Compound 4: middle estimate off by 1.1-fold (0.02 log units), on the high side, within the range that was stated.
By their numbers in this assay, from the lowest: compounds 3, 1 and 4 (each within the scatter of the next, the first and the last beyond it); then compound 2.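

The arm next to the ring sulfur can carry a substituent on its phenyl without a clear loss against the thiophen-2-yl of compound 1 in this assay, with a 1.9-fold higher number from compound 1 to compound 4 (0.28 log units; within the scatter). Against the plain phenyl, the methoxy group does make a difference, with a 3.2-fold higher number from compound 3 to compound 4 (0.51 log units; beyond the scatter), yet 3-methoxyphenyl is clearly better tolerated here than 4-chlorophenyl, with a 4.5-fold lower number from compound 2 to compound 4 (0.66 log units; beyond the scatter). So a substituent on this phenyl need not carry the large penalty seen with the chloro group, though nothing available explains why these groups differ.

Compounds 2 and 4 differ both in the group and in where it sits on the phenyl, so the gap between them could come from either, and a 4-methoxyphenyl or a 3-chlorophenyl arm would be needed to tell the two apart. Also open, as far as these compounds go, is how this position would respond to a phenyl bearing an amine or a carboxylic acid, or to a longer chain in place of the methoxy group.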